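A Five-Membered Ring Enters in Place of a Small Group

The source may report more compounds than this note shows. Statements on the series, on what has been measured and on what is new or still open speak of the compounds shown alone.

In an ADME assay on H9c2 cells (Rattus norvegicus) for cytotoxicity, read by MTT assay, with a stated time of 48 h (a higher number here means a weaker inhibitor, a lower number a stronger inhibitor), compound 2 (`NC(=S)c1ccc(OC(=O)c2cccnc2)cc1`) gives 754000 nM and compound 3 (`Cc1ccc(NC(=S)OCCNC(=O)C(C)(C)Oc2ccc(Cl)cc2)cc1`) gives 771000 nM, two numbers within the scatter of each other. Compound 1 (`O=C(NCCOC(=S)Nc1ccccc1)c1cccnc1`) gives > 800000 nM, which is a limit of the assay and not a number. Compound 4 (`O=C(Oc1ccc(-c2cc(=S)ss2)cc1)c1cccnc1`) departs from compound 2 at one place, on an aromatic carbon of a six-membered aromatic ring of carbon only: a group of 6 heavy atoms (3 carbon, 3 sulfur; one five-membered aromatic ring with 2 hetero atoms) in place of a group of 3 heavy atoms (1 carbon, 1 nitrogen, 1 sulfur; no ring), on an aromatic carbon. For the measured compounds named here, no measured pair here shows what such a change does, so the expectation starts from compound 2 at 754000 nM and points to a lower number in this assay, somewhat beyond the scatter. The expected move is a 3.0-fold lower number from compound 2 to compound 4 (0.48 log units; beyond the scatter). For compound 4 the estimated value is 250000 nM, with an expected range of 50000 nM to 700000 nM.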

Compound 4, half-maximal inhibitory concentration: 627000 nM
The estimate for compound 4 lay 2.5-fold (0.40 log units) below the measured number; the range from low to high includes it.
By their numbers in this assay, from the lowest: compounds 4, 2 and 3 (each within the scatter of the next). At a limit, above all of these: compound 1.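

For the compounds shown here, this is the first step read at this position, an aromatic carbon of a six-membered aromatic ring of carbon only. In this assay, the five-membered aromatic ring with 2 hetero atoms entering in place of the small open group gives a 1.2-fold lower number from compound 2 to compound 4 (0.08 log units; within the scatter), so a larger ring at this carbon brings no readable difference. Compound 1 stands at a limit of the assay, so it offers no number for comparison: the limit of > 800000 nM in this assay, at which 1 of the 4 values shown sits.

The compounds shown leave open whether a different group at this carbon, such as an amine or a carboxylic acid, would give a step beyond the scatter. They also leave open whether a six-membered ring there would behave as this five-membered ring does.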